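Methoxy to hydroxy on the aryl ring of compound 2

A few compounds are considered here, and "the series" means these few. Any claim that something is new, unique, unknown or untested is made for them only; others in the source may bear on it.

Measured compounds and growth-inhibition values:
compound 1 `COc1cc(C)cc(-c2c(-c3ccnc(-c4ccc(N(C)C)cc4)c3)cnn2CC#N)c1` — 54.1 nM
compound 2 `COc1cc(C)cc(-c2nn(CC#N)cc2-c2ccnc(-c3ccc(N(C)C)cc3)c2)c1` — 258 nM
compound 3 `COc1cc(C)cc(-c2nn(CC#N)cc2-c2ccc(-c3cccc(C(C)=O)c3)nc2)c1` — 1170 nM

In a functional assay on M14 cells (Homo sapiens) for inhibition, read by sulforhodamine B assay, with a stated time of 48 h (on this read-out higher numbers stand for weaker inhibition of growth and lower numbers for stronger inhibition of growth), compound 2 gives 258 nM, the second highest of the three numbers. Compound 1 lies lower at 54.1 nM and compound 3 lies higher at 1170 nM, both gaps beyond the scatter of this assay.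

Compound 4 `Cc1cc(O)cc(-c2nn(CC#N)cc2-c2ccnc(-c3ccc(N(C)C)cc3)c2)c1` differs from compound 2 in one place: hydrogen in place of methyl on an oxygen on an aromatic ring. Within the data shown here, no measured pair in this set carries the same change, so nothing here shows how the shared core responds to it. The step of a 1.4-fold higher number from compound 2 to compound 4 (0.13 log units; within the scatter) is expected to be small, toward weaker inhibition of growth if anything, and may well stay within the scatter. Compound 4 is estimated at 350 nM, with a range from 120 nM to 1000 nM.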

Compound 4, concentration for 50% growth inhibition: 1830 nM
Estimate against measurement, compound 4: 5.2-fold (0.72 log units) below; the measured number lies above the stated range.
By their numbers in this assay, from the lowest: compound 1; then compound 2; then compounds 3 and 4 (each within the scatter of the next).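

In this assay, among these compounds, the change from methoxy to hydroxy on the aryl ring is not neutral: a 7.1-fold higher number from compound 2 to compound 4 (0.85 log units; beyond the scatter) gives the first single-place step in this set, and it runs toward weaker inhibition of growth. The methyl on this oxygen therefore matters for growth inhibition on the core of compound 2, though this one pair says nothing about other cores. No measurement at hand accounts for the step.

Still open, going by these compounds, is whether an ethoxy group, an amine or a fluorine at this place would hold the value of compound 2 or lose as much as the hydroxy group. Also open, on these data alone, is whether methoxy to hydroxy costs as much on the core of compound 1.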